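The source may hold more compounds than are shown below. What is called first, only, known or untested is meant among the compounds shown, and "the series" means these compounds.

Compound 1 `CCOC(c1ccccc1)c1ccc(C(C)C)cc(=O)c1O` gives 0.3 ug/mL in a functional assay on KB cells (Homo sapiens) for inhibition; on this read-out higher numbers stand for weaker inhibition and lower numbers for stronger inhibition. Compound 2 `CCOC(c1ccc(OC)cc1)c1ccc(C(C)C)cc(=O)c1O` gives 0.5 ug/mL in this assay, the higher of the two numbers, yet the step of a 1.7-fold higher number from compound 1 to compound 2 (0.22 log units; within the scatter) means the two compounds cannot be told apart. Compound 3 `COc1ccc(C(NC(C)=O)c2ccc(C(C)C)cc(=O)c2O)cc1` carries acetamido in place of ethoxy on a saturated chain carbon bound to two aromatic carbons. For the measured compounds named here, the one measured step concerns methoxy in place of hydrogen on an aromatic carbon and does not bear on a swap at this chain carbon, so no step in this assay offers guidance here. Compound 3 is therefore expected to move little, the step of no change at the digits printed from compound 2 to compound 3 (within the scatter) being estimated only loosely, giving an estimate of 0.5 ug/mL within 0.15 ug/mL to 1.6 ug/mL.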

Compound 3, concentration for 50% inhibition: 6 ug/mL
Compound 3: middle estimate off by 12-fold (1.08 log units), on the low side; the measured number lies above the stated range.
By their numbers in this assay, from the lowest: compounds 1 and 2 (each within the scatter of the next); then compound 3.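

Replacing ethoxy with acetamido on the saturated chain carbon bound to two aromatic carbons gives a 12-fold higher number from compound 2 to compound 3 (1.08 log units; beyond the scatter) in this assay and so clearly weakens inhibition. This shows that the group on this carbon can matter, which the methoxy change on the aromatic carbon did not reveal. No measurement shown here explains the loss.

From the compounds shown here alone, whether an amine, a hydroxyl or a longer ether chain on this carbon would behave like ethoxy or like acetamido remains open. Going by these compounds, it is also open whether the same swap would cost as much without the methoxy, as in compound 1.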